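From difluoromethyl to methyl: a clearance question for compound 4

This account rests on a few compounds, and the source may have more. Where it says the series, first, only, none or still open, it means among the compounds named here.

For the measured compounds named here, in an in vitro ADME assay on microsomes from liver (Homo sapiens) for metabolic stability (a lower number here means slower removal, a higher number faster removal of the compound), compound 1 (`Fc1ccccc1Cc1nc(-c2nc(C(F)F)n[nH]2)n2ccccc12`) gives 62 mL.min-1.g-1, the higher of the two numbers available so far. Compound 3 (`Fc1ccccc1Cc1nc(-c2nc(C(F)(F)F)n[nH]2)c2ccccn12`) gives 20 mL.min-1.g-1, a gap beyond the usual scatter of repeated measurements. For compound 2 (`Fc1ccccc1Cc1nc(-c2nc(C(F)(F)F)n[nH]2)c2cccnn12`) the entry reads "not determined" (no result reported), so it adds no number to the comparison.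

Compound 4 (`Cc1n[nH]c(-c2nc(Cc3ccccc3F)c3ccccn23)n1`) has yet to be measured. It differs from compound 1 by a single structural change: methyl in place of difluoromethyl on an aromatic carbon. The rest of the molecule stays the same.

Going by the values given here, no measured pair of compounds shows this change on its own, so there is no direct precedent for its size. Among the compounds with values here, the only anchor is compound 1 at 62 mL.min-1.g-1, and no step beyond the scatter is expected in this assay. The expected step is a 1.2-fold lower number from compound 1 to compound 4 (0.09 log units; within the scatter), a small decrease that stays within the scatter. For compound 4 the estimated value is 50 mL.min-1.g-1, with an expected range of 22 mL.min-1.g-1 to 110 mL.min-1.g-1.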

Compound 4, intrinsic clearance in microsomes: 124 mL.min-1.g-1
Compound 4: middle estimate off by 2.5-fold (0.39 log units), on the low side, outside the stated range (above it).
By their numbers in this assay, from the lowest: compound 3; then compounds 1 and 4 (each within the scatter of the next).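

Placing methyl where difluoromethyl stood, on the aromatic carbon between two ring nitrogen atoms, gives in this assay a 2.0-fold higher number from compound 1 to compound 4 (0.30 log units; within the scatter). For the compounds shown here, this is the first direct reading of the swap at this position, and on this single pair, the two compounds cannot be told apart in this assay. Removing the two fluorine atoms thus produces no difference here that exceeds the normal spread of repeat measurements, and nothing available explains this outcome.

This single pair leaves open how the assay would respond to quite different groups on the same carbon, such as an amine, a carboxylic acid or a longer chain. It also cannot show whether the swap from difluoromethyl to methyl would give a similar result on a different core.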